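Ethyl to Trifluoroethyl on a Shared Core

A few compounds are considered here, and "the series" means these few. Any claim that something is new, unique, unknown or untested is made for them only; others in the source may bear on it.

Compound 3 `CCc1cnc2c(C#N)c(N3CCN(c4ncccn4)CC3)ccn12` carries an ethyl group on the saturated chain carbon bound to an aromatic carbon. In a functional assay on CHO cells with metabotropic glutamate receptor 2 (Homo sapiens) as the target, read by GTPgammaS binding (on this read-out higher numbers stand for an effect only at larger amounts of compound and lower numbers for an effect already at smaller amounts), compound 3 reaches only the limit of the assay, > 3160 nM, and gives no number. Its nearest measured neighbour is compound 2 `CCCc1cnc2c(C#N)c(N3CCN(c4ncccn4)CC3)ccn12`, which in this assay likewise stops at a limit, > 3160 nM. The step that the two limits leave unreadable from compound 2 to compound 3 therefore stays unreadable, as the limit of > 3160 nM in this assay, at which 2 of the 3 values shown sit, shows. Compound 4 `N#Cc1c(N2CCN(c3ncccn3)CC2)ccn2c(CC(F)(F)F)cnc12` differs from compound 3 by trifluoromethyl in place of methyl on a saturated chain carbon bound to an aromatic carbon. Among the compounds with values here, no measured step covers this change directly. Compound 1 `Cc1cc(C)nc(N2CCN(c3ccn4c(CC(F)(F)F)cnc4c3C#N)CC2)n1` bears the same trifluoroethyl group, yet differs from compound 4 in a second place as well; in this assay compound 1 gives 447 nM. That value shows that a compound carrying this group can reach a measurable number. Compound 4 is therefore expected to lie around 2000 nM, within 600 nM to 6000 nM, with a fair chance that only a limit is reported. The expected step of an at least 1.5-fold lower number from compound 3 to compound 4 (0.19 log units; that floor lies within the scatter) thus points toward an effect at a smaller amount of compound, though from a limit its size cannot be fixed.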

Compound 4, half-maximal effective concentration: 851 nM
The estimate for compound 4 lay 2.4-fold (0.37 log units) above the measured number; low and high end bracket the measured number.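

In this assay, trifluoromethyl in place of methyl on a saturated chain carbon bound to an aromatic carbon gives an at least 3.7-fold lower number from compound 3 to compound 4 (0.56 log units; beyond the scatter) and trifluoromethyl in place of ethyl gives an at least 3.7-fold lower number from compound 2 to compound 4 (0.56 log units; beyond the scatter) on the shared core, so this position does respond to the change. Compound 2 and compound 3 each stop at a limit, so these two steps are floors rather than sizes because only one end of each is a number: the limit of > 3160 nM in this assay, at which 2 of the 4 values shown sit. Pyrimidin-2-yl in place of 4,6-dimethylpyrimidin-2-yl on an amine nitrogen in a ring gives a 1.9-fold higher number from compound 1 to compound 4 (0.28 log units; within the scatter), so the 2,2,2-trifluoroethyl group comes with a measurable number alongside either group.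

From the compounds shown here alone, the step between compound 2 and compound 3 cannot be read, and the full size of the two floors stays open. Going by these compounds, whether a chain ending in an amine or a carboxylic acid at this position would also give a number stays open too.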